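A few compounds are considered here, and "the series" means these few. Any claim that something is new, unique, unknown or untested is made for them only; others in the source may bear on it.

Compound 1 `CCCCn1ncc(OCc2nnc(-c3ccccc3)o2)c(Cl)c1=O`: in a functional assay on the whole organism for inhibition, with Mythimna separata as the target, with a stated time of 5 days (on this read-out lower numbers stand for an effect already at smaller amounts and higher numbers for an effect only at larger amounts of compound), compound 1 gives > 299000 nM, which is a limit of the assay rather than a number. Compound 2 `CCn1ncc(OCc2nnc(-c3ccccc3)o2)c(Cl)c1=O`: compound 2 gives > 299000 nM, again a limit. Compound 3 `CC(C)(C)n1ncc(OCc2nnc(-c3ccccc3)o2)c(Cl)c1=O`: compound 3 gives 12200 nM.

Compound 3 thus carries the only number shown; the other two values are limits, as the limit of > 299000 nM in this assay, at which 2 of the 3 values shown sit, states. Compound 4 `O=c1c(Cl)c(OCc2nnc(-c3ccccc3)o2)cnn1-c1ccccc1` differs from compound 3 by phenyl in place of tert-butyl on an aromatic nitrogen. The two measured steps that bear on this position, an at least 24-fold lower number from compound 1 to compound 3 (1.38 log units; beyond the scatter) and an at least 24-fold lower number from compound 2 to compound 3 (1.38 log units; beyond the scatter), each moved from a straight chain to tert-butyl with a large gain. For the measured compounds named here, no measured step reaches a phenyl, so the size of the step is uncertain. For compound 4 a modest loss is expected, a 2.0-fold higher number from compound 3 to compound 4 (0.31 log units; beyond the scatter), giving an estimated value of 25000 nM, ranging from 4000 nM to 200000 nM.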

Compound 4, half-maximal effective concentration: 91400 nM
Compound 4: the middle estimate sits 3.7-fold (0.56 log units) below what was measured; the measured number falls inside the stated range.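

With an at least 3.2-fold lower number from compound 2 to compound 4 (0.51 log units; beyond the scatter) and an at least 3.2-fold lower number from compound 1 to compound 4 (0.51 log units; beyond the scatter) as its steps, phenyl shows that a ring on this aromatic nitrogen can beat the straight chains, not only the branched tert-butyl. With a 7.5-fold higher number from compound 3 to compound 4 (0.87 log units; beyond the scatter) phenyl still falls short of tert-butyl at this position. The two steps from the straight chains give only a minimum size, as compounds 1 and 2 stand at a limit of the assay and not at a number: the limit of > 299000 nM in this assay, at which 2 of the 4 values shown sit.

Open, going by these compounds, is whether a smaller branched chain such as isopropyl would come close to tert-butyl. Also open, on these data alone, is whether a methoxy group on the phenyl ring would shift the number.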